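This account rests on a few compounds, and the source may have more. Where it says the series, first, only, none or still open, it means among the compounds named here.

In a functional assay on MCF7 cells (Homo sapiens) for inhibition, read by MTT assay, with a stated time of 72 h (a lower number here means a stronger inhibitor, a higher number a weaker inhibitor), compound 1 `CCCCc1ccc(NC(=O)C2CCN(C/C=C/c3ccccc3)CC2)cc1` gives 5870 nM, compound 2 `CCCCCc1ccc(NC(=O)C2CCN(C/C=C/c3ccccc3)CC2)cc1` gives 3740 nM and compound 3 `O=C(Nc1cccc(Br)c1)C1CCN(C/C=C/c2ccccc2)CC1` gives 11500 nM. The number for compound 3 lies within the scatter of compound 1 but clearly above that of compound 2. Compound 4 `N#Cc1ccc(NC(=O)C2CCN(C/C=C/c3ccccc3)CC2)cc1` has 4-cyanophenyl in place of 3-bromophenyl on an amide-type nitrogen. For the measured compounds named here, the only measured step, a 1.6-fold lower number from compound 1 to compound 2 (0.20 log units; within the scatter), merely extends a saturated chain, and no measured compound carries a nitrile, so it offers little guidance for this swap. In this assay, no change beyond the scatter is expected, and the estimated step is a 1.3-fold lower number from compound 3 to compound 4 (0.11 log units; within the scatter). Compound 4 is expected at about 9000 nM, with an estimated range of 3000 nM to 27000 nM.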

Compound 4, half-maximal inhibitory concentration: 44500 nM
Beside the measured number, compound 4's estimate is 4.9-fold (0.69 log units) below it, and the stated range ends below it.
By their numbers in this assay, from the lowest: compounds 2, 1 and 3 (each within the scatter of the next, the first and the last beyond it); then compound 4.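

In this assay, the group on the amide-type nitrogen clearly matters: 4-cyanophenyl in place of 3-bromophenyl gives a 3.9-fold higher number from compound 3 to compound 4 (0.59 log units; beyond the scatter) and so a weaker inhibitor. Cyano in place of butyl on the aromatic carbon gives a 7.6-fold higher number from compound 1 to compound 4 (0.88 log units; beyond the scatter), and cyano in place of pentyl gives a 12-fold higher number from compound 2 to compound 4 (1.08 log units; beyond the scatter), which sets compound 4 apart from all three earlier compounds. Nothing available explains this loss. Compound 4 differs from compound 3 in both the group and its place on the ring, so these compounds cannot separate the two. From the compounds shown here alone, how an amine or a carboxylic acid on that ring would compare also stays open.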